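Adding a Third Methoxy Group: Measured Results and One Expectation

A few compounds are considered here, and "the series" means these few. Any claim that something is new, unique, unknown or untested is made for them only; others in the source may bear on it.

Compound 1 `Cc1ncc([N+](=O)[O-])n1CCSc1nnc(-c2ccccc2O)o1` was tested in a functional assay on SGC-7901 cells (Homo sapiens) for cytotoxicity, read by MTT assay, with a stated time of 48 h (on this read-out higher numbers stand for weaker inhibition and lower numbers for stronger inhibition), where compound 1 gave 30500 nM. Compound 2 `COc1ccc(-c2nnc(SCCn3c([N+](=O)[O-])cnc3C)o2)c(O)c1` differs from compound 1 by methoxy in place of hydrogen on an aromatic carbon, and in this assay compound 2 gave 11700 nM; the step of a 2.6-fold lower number from compound 1 to compound 2 (0.42 log units; beyond the scatter). Compound 3 `COc1cc(OC)cc(-c2nnc(SCCn3c([N+](=O)[O-])cnc3C)o2)c1` gave 9600 nM in this assay; the difference between the core of compound 3 and the core of compound 1 is not broken down here. Compound 4 `COc1cc(-c2nnc(SCCn3c([N+](=O)[O-])cnc3C)o2)cc(OC)c1OC` has not yet been measured. It differs from compound 3 by methoxy in place of hydrogen on an aromatic carbon, the same kind of change as from compound 1 to compound 2, though here the place is ortho to two methoxy groups rather than meta to a hydroxy group. Resting on the earlier step of a 2.6-fold lower number from compound 1 to compound 2 (0.42 log units; beyond the scatter), compound 4 is expected to show a 1.4-fold lower number from compound 3 to compound 4 (0.14 log units; within the scatter) in this assay. Compound 4 is therefore estimated at 7000 nM, between 3000 nM and 18000 nM.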

Compound 4, half-maximal inhibitory concentration: 34800 nM
Compound 4: the middle estimate sits 5.0-fold (0.70 log units) below what was measured; measured number above the stated range.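

On the core of compound 3, methoxy in place of hydrogen on an aromatic carbon gave a 3.6-fold higher number from compound 3 to compound 4 (0.56 log units; beyond the scatter) in this assay, so the earlier lowering did not carry over. The two steps run in opposite directions and differ clearly: the same change on two cores in this assay, a 2.6-fold lower number (0.42 log units; beyond the scatter) from compound 1 to compound 2 and a 3.6-fold higher number (0.56 log units; beyond the scatter) from compound 3 to compound 4, 9.4-fold (0.98 log units) apart, beyond the scatter of two such steps

This shows that, in these two pairs, the outcome of the change was not fixed by the incoming methoxy alone, but it does not show why, since the place on the ring and the surrounding core differ together between the pairs. The compounds shown leave open how an amine or a carboxylic acid would behave at the place ortho to two methoxy groups. They also leave open whether a longer chain there would follow either step.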